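Fluoro in Place of Hydrogen on Two Related Cores

This account rests on a few compounds, and the source may have more. Where it says the series, first, only, none or still open, it means among the compounds named here.

Four compounds share much of their framework. Compound 1 `N/C(=N\NC(=S)N1CCCCCC1)c1ccccn1` and compound 2 `N/C(=N\NC(=S)N1CCSCC1)c1ccccn1` have different cores; how these two cores differ is not broken down here. In a functional assay on MCF7 cells (Homo sapiens) for cytotoxicity, read by MTT assay, with a stated time of 72 h, tested at 10 uM (a lower number here means less inhibition of growth, a higher number more inhibition of growth at the concentration tested), compound 1 gives 62.2%, and in the same test compound 2 gives 54.3%, two numbers that lie within the usual scatter of each other. Compound 3 `N/C(=N\NC(=S)N1CCSCC1)c1ccc(F)cn1` carries the change fluoro in place of hydrogen on an aromatic carbon on the core of compound 2, and in this assay compound 3 gives 38.1%; that step is a number 16.2 percentage points lower from compound 2 to compound 3 (beyond the scatter). Compound 4 `N/C(=N\NC(=S)N1CCCCCC1)c1ccc(F)cn1` carries the same change, (fluoro in place of hydrogen on an aromatic carbon), on the core of compound 1. Because the step to compound 3 was a number 16.2 percentage points lower from compound 2 to compound 3 (beyond the scatter), a step of about a number 16.2 percentage points lower from compound 1 to compound 4 (beyond the scatter) is expected in this assay. Compound 4 is accordingly estimated to give 46% in this assay.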

Compound 4, percent growth inhibition at one concentration: 26.8%
Compound 4: the middle estimate sits 19.2 percentage points above what was measured; the measured number lies below the stated range.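

On the core of compound 1, fluoro in place of hydrogen gives a number 35.4 percentage points lower from compound 1 to compound 4 (beyond the scatter) in this assay. The direction of the change carries over between the two cores, but its size does not: the same change on two cores in this assay, a number 16.2 percentage points lower (beyond the scatter) from compound 2 to compound 3 and a number 35.4 percentage points lower (beyond the scatter) from compound 1 to compound 4, 19.2 percentage points apart, beyond the scatter of two such steps. These two pairs show that a step measured on one core did not give a reliable size for the other, but they do not show why the cores respond differently or whether the shared direction would hold on any further core.

The compounds shown leave open how other groups on the same aromatic carbon, such as chloro, methyl or an amine, would behave. On these data alone, it also remains open whether their steps would depend on the core as well.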